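Opening notes on a pyrrolo-fused lactam series, compound 4

A few compounds are considered here, and "the series" means these few. Any claim that something is new, unique, unknown or untested is made for them only; others in the source may bear on it.

Measured so far in an assay on CHO cells for displacement of a labelled ligand from Substance-P receptor (Homo sapiens), in the presence of a further agent that is not named here; a higher number here means a weaker inhibitor, a lower number a stronger inhibitor:
compound 1 `C[C@@H](O[C@H]1CN2C(=O)C=C(c3ccc(NS(C)(=O)=O)cc3)CC2[C@@H]1c1ccc(F)cc1)c1cc(C(F)(F)F)cc(C(F)(F)F)c1` gives 54 nM
compound 2 `COc1cc(C2=CC(=O)N3C[C@H](O[C@H](C)c4cc(C(F)(F)F)cc(C(F)(F)F)c4)[C@@H](c4ccc(F)cc4)C3C2)ccn1` gives 44 nM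
compound 3 `C[C@@H](O[C@H]1CN2C(=O)C=C(c3ccc[n+]([O-])c3)CC2[C@@H]1c1ccc(F)cc1)c1cc(C(F)(F)F)cc(C(F)(F)F)c1` gives 2.3 nM

Compound 1 stands highest of the measured numbers. Its nearest neighbour is compound 2, a 1.2-fold lower number from compound 1 to compound 2 (0.09 log units; within the scatter), a change of 2-methoxypyridin-4-yl in place of 4-(methanesulfonamido)phenyl on a double-bonded ring carbon. The furthest is compound 3, a 23-fold lower number from compound 1 to compound 3 (1.37 log units; beyond the scatter), and likewise a 19-fold lower number from compound 2 to compound 3 (1.28 log units; beyond the scatter), both large and beyond the scatter.

Compound 4 `C[C@@H](O[C@H]1CN2C(=O)C=C(c3cnn(Cc4ccccc4)c3)CC2[C@@H]1c1ccc(F)cc1)c1cc(C(F)(F)F)cc(C(F)(F)F)c1` differs from compound 1 at the same position: 1-benzyl-1H-pyrazol-4-yl in place of 4-(methanesulfonamido)phenyl on a double-bonded ring carbon. Both measured steps from compound 1 swap the group on that double-bonded ring carbon, so both bear on this change, but neither introduces 1-benzyl-1H-pyrazol-4-yl. One swap left the number where it was, the other lowered it considerably. Among the measured compounds shown here, with no closer precedent, a step of either size cannot be ruled out, and the expected step of a 1.4-fold lower number from compound 1 to compound 4 (0.13 log units; within the scatter) is set near no change, with a wide range toward lower numbers.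

Compound 4 is therefore estimated at 40 nM, between 8 nM and 200 nM.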

Compound 4, half-maximal inhibitory concentration: 66 nM
The estimate for compound 4 lay 1.7-fold (0.22 log units) below the measured number, within the range that was stated.
By their numbers in this assay, from the lowest: compound 3; then compounds 2, 1 and 4 (each within the scatter of the next).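

In this assay, a pyrazole carrying a benzyl group, with a five-membered aromatic ring and a second ring further out, is accepted on this double-bonded ring carbon without a step beyond the scatter, both against 4-(methanesulfonamido)phenyl (a 1.2-fold higher number from compound 1 to compound 4 (0.09 log units; within the scatter)) and against 2-methoxypyridin-4-yl (a 1.5-fold higher number from compound 2 to compound 4 (0.18 log units; within the scatter)). Three differently built groups thus give numbers within the scatter of one another, and compound 3 goes against this pattern, its distance now seen again on the step to the pyrazole (a 29-fold higher number from compound 3 to compound 4 (1.46 log units; beyond the scatter)), so the large step is not confined to the first two groups tried against compound 3. Nothing available here accounts for what sets the group of compound 3 apart from the other three.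

Open, as far as these compounds go, is how pyridin-3-yl, carrying no oxygen, would stand against compound 3, which would show whether the low number follows the oxygen or the ring itself. Also open, from the compounds shown here alone, is whether the benzyl group contributes at all, a question that 1H-pyrazol-4-yl or 1-methyl-1H-pyrazol-4-yl on the same carbon would address.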